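From 4-methylphenyl to 4-propylphenyl: an expected flat step

A few compounds are considered here, and "the series" means these few. Any claim that something is new, unique, unknown or untested is made for them only; others in the source may bear on it.

In a functional assay on HCT-116 cells (Homo sapiens) for antiproliferative activity, read by CCK-8 assay, with a stated time of 72 h (on this read-out higher numbers stand for weaker inhibition and lower numbers for stronger inhibition), compound 1 `Nc1ccccc1NC(=O)c1ccc(COc2ccc([N+](=O)[O-])cc2)cc1` gives > 32000 nM, which is a limit of the assay and not a number. Compound 2 `Cc1ccc(OCc2ccc(C(=O)Nc3ccccc3N)cc2)cc1` gives 4860 nM, and compound 3 `CC(C)c1ccc(OCc2ccc(C(=O)Nc3ccccc3N)cc2)cc1` gives 4570 nM. For the measured compounds named here, these are the only two true numbers so far, and they lie within the scatter of each other.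

Compound 4 `CCCc1ccc(OCc2ccc(C(=O)Nc3ccccc3N)cc2)cc1` differs from compound 2 by ethyl in place of hydrogen on a saturated chain carbon bound to an aromatic carbon, so that 4-methylphenyl becomes 4-propylphenyl. The closest measured change is isopropyl in place of methyl on an aromatic carbon, seen in a 1.1-fold lower number from compound 2 to compound 3 (0.03 log units; within the scatter), and that step stays within the scatter. The larger steps, an at least 6.5-fold lower number from compound 1 to compound 2 (0.81 log units; beyond the scatter) and an at least 7.0-fold lower number from compound 1 to compound 3 (0.84 log units; beyond the scatter), both start from nitro and speak to a different kind of change. Going by compound 3 at 4570 nM, no shift beyond the scatter is expected here.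

The expected step is a 1.1-fold lower number from compound 2 to compound 4 (0.03 log units; within the scatter). For compound 4 the estimated value is 4500 nM, with an expected range of 2200 nM to 9500 nM.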

Compound 4, half-maximal inhibitory concentration: 3230 nM
Beside the measured number, compound 4's estimate is 1.4-fold (0.14 log units) above it; measured number inside the range.
By their numbers in this assay, from the lowest: compounds 4, 3 and 2 (each within the scatter of the next). At a limit, above all of these: compound 1.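

In this assay the ethyl on the saturated chain carbon bound to an aromatic carbon gives no shift beyond the scatter, with a 1.5-fold lower number from compound 2 to compound 4 (0.18 log units; within the scatter) as the step, and propyl in place of isopropyl likewise, with a 1.4-fold lower number from compound 3 to compound 4 (0.15 log units; within the scatter) as the step. Methyl, isopropyl and propyl thus cannot be told apart here, and a straight chain reads like a branched one, which compound 2 and compound 3 alone could not show. Propyl also stands apart from nitro, with an at least 9.9-fold lower number from compound 1 to compound 4 (0.99 log units; beyond the scatter) as the step, but that step is only a bound, since compound 1 sits at a limit of the assay and not at a number: the limit of > 32000 nM in this assay, at which 1 of the 4 values shown sits.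

On these data alone, whether a longer chain such as butyl, an amine or a carboxylic acid would stay with these values remains open. As far as these compounds go, whether nitro stands apart alone, or a nitrile or a methoxy group would go with it, also remains open.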